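A few compounds are considered here, and "the series" means these few. Any claim that something is new, unique, unknown or untested is made for them only; others in the source may bear on it.

Compound 1 `OC[C@H]1O[C@@H](n2cc(F)c3c(-c4cccs4)ncnc32)[C@H](O)[C@@H]1O` carries a thiophen-2-yl group. In an ADME assay on BJ cells (Homo sapiens) for cytotoxicity, read by MTT assay, with a stated time of 72 h (a lower number here means that less compound is tolerated, a higher number that more compound is tolerated), compound 1 gives 170 nM. Compound 2 `OC[C@H]1O[C@@H](n2cc(F)c3c(-c4ccsc4)ncnc32)[C@H](O)[C@@H]1O` differs from it only by thiophen-3-yl in place of thiophen-2-yl on an aromatic carbon, and in this assay compound 2 gives 620 nM, so that a 3.6-fold higher number from compound 1 to compound 2 (0.56 log units; beyond the scatter). Compound 3 `CCCCCCCCCCCCCCCCCCOP(=O)(O)OC[C@H]1O[C@@H](n2ccc3c(-c4cccs4)ncnc32)[C@H](O)[C@@H]1O` has a different core, with a long phosphate-bearing chain on the sugar and no fluorine; the difference between the two cores is not broken down here. In this assay compound 3 gives "not determined" (no result reported), so for compound 3 no single number is reported. Compound 4 `CCCCCCCCCCCCCCCCCCOP(=O)(O)OC[C@H]1O[C@@H](n2ccc3c(-c4ccsc4)ncnc32)[C@H](O)[C@@H]1O` stands to compound 3 as compound 2 stands to compound 1, by thiophen-3-yl in place of thiophen-2-yl on an aromatic carbon, at the same place. For the measured compounds named here, a step of similar direction is expected for compound 4 because a 3.6-fold higher number from compound 1 to compound 2 (0.56 log units; beyond the scatter) is the only guide available, though compound 3 gives no anchor. Compound 4 is therefore estimated at 1500 nM in this assay, within 300 nM to 8000 nM.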

Compound 4, half-maximal cytotoxic concentration: > 50000 nM
Compound 4 ended at the assay's limit; the forecaster's own chance of this, stated with the estimate: 30%; middle value at least 33-fold (1.52 log units) away from the limit.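

Compound 4 gives > 50000 nM, which is a limit of the assay and not a number. For the compounds shown here, with no result reported for compound 3, no step between compound 3 and compound 4 can be read. As far as these compounds go, whether thiophen-3-yl in place of thiophen-2-yl acts on the core of compound 3 as it does on the core of compound 1 stays open.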